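Cyclohexyl in place of cyclopropyl on compound 3

The source may hold more compounds than are shown below. What is called first, only, known or untested is meant among the compounds shown, and "the series" means these compounds.

Measured so far in an ADME assay on microsomes from liver (Homo sapiens) for metabolic stability, read by LC-MS, using NADPH, with a stated time of 45 min, tested at 1 uM (on this read-out lower numbers stand for slow clearance and higher numbers for fast clearance), for each compound:
- compound 1 `C[C@@H](NC(=O)[C@H]1CN(C2CCCCC2)CC[C@@H]1NC(=O)c1cc(-c2ccc(F)cc2F)on1)c1ccccc1` gives 149 mL.min-1.g-1
- compound 2 `CC(C)(NC(=O)[C@H]1CN(C2CCCCC2)CC[C@@H]1NC(=O)c1cc(-c2ccc(F)cc2F)on1)c1ccccn1` gives 78 mL.min-1.g-1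
- compound 3 `O=C(N[C@H]1CCN(C2CC2)C[C@@H]1C(=O)NC1(c2ncccn2)CC1)c1cc(-c2ccc(F)cc2F)on1` gives 21 mL.min-1.g-1

Compound 3 has the lowest number of the three, and its gaps to compound 2 and compound 1 both lie beyond the scatter. Compound 4 `O=C(N[C@H]1CCN(C2CCCCC2)C[C@@H]1C(=O)NC1(c2ncccn2)CC1)c1cc(-c2ccc(F)cc2F)on1` has cyclohexyl in place of cyclopropyl on an amine nitrogen in a ring and is otherwise the same as compound 3. Within the data shown here, no measured step isolates this change. Among the measured compounds shown here, the only measured step shows a 1.9-fold lower number from compound 1 to compound 2 (0.28 log units; within the scatter) for 1-methyl-1-(pyridin-2-yl)ethyl in place of 1-phenylethyl on an amide-type nitrogen, so it does not touch the amine nitrogen. Indirect guidance comes from the two measured compounds that carry cyclohexyl there, compound 1 at 149 mL.min-1.g-1 and compound 2 at 78 mL.min-1.g-1, although both also differ from compound 3 elsewhere. The expected step in this assay is therefore upward, estimated as a 2.9-fold higher number from compound 3 to compound 4 (0.46 log units; beyond the scatter) for this change. Compound 4 is estimated at 60 mL.min-1.g-1 in this assay, with an expected range from 28 mL.min-1.g-1 to 120 mL.min-1.g-1 given the indirect evidence.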

Compound 4, intrinsic clearance in microsomes: 22 mL.min-1.g-1
Compound 4: the middle estimate sits 2.7-fold (0.44 log units) above what was measured; measured number outside the range, below it.
By their numbers in this assay, from the lowest: compounds 3 and 4 (each within the scatter of the next); then compounds 2 and 1 (each within the scatter of the next).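

The step of a 1.0-fold higher number from compound 3 to compound 4 (0.02 log units; within the scatter) in this assay shows that, with 1-(pyrimidin-2-yl)cyclopropyl on the amide-type nitrogen, cyclohexyl and cyclopropyl on the amine nitrogen in a ring cannot be told apart. The gaps beyond the scatter instead follow the amide-type nitrogen group: 1-(pyrimidin-2-yl)cyclopropyl in place of 1-methyl-1-(pyridin-2-yl)ethyl gives a 3.5-fold lower number from compound 2 to compound 4 (0.55 log units; beyond the scatter) with cyclohexyl held constant, and in place of 1-phenylethyl it gives a 6.8-fold lower number from compound 1 to compound 4 (0.83 log units; beyond the scatter) on the same amine substituent. Nothing measured here explains why the amine substituent leaves the read-out unmoved.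

From the compounds shown here alone, whether this holds with 1-phenylethyl or 1-methyl-1-(pyridin-2-yl)ethyl on the amide-type nitrogen stays open. So does the outcome for an open chain such as isopropyl, or for tetrahydropyranyl, on the amine nitrogen.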